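The compounds below may be only part of what the source reports. "The series", "measured", "known", "first", "only" and "open" are said of these compounds alone.

In an assay on isolated protein for displacement of a labelled ligand from 5-hydroxytryptamine receptor 6 (Homo sapiens) (on this read-out lower numbers stand for stronger inhibition and higher numbers for weaker inhibition), compound 1 `CN(C)CC1CCCc2cc(S(=O)(=O)c3ccccc3)ccc21` gives 0.0631 nM. Compound 2 `O=C(NC[C@@H]1CCCc2cc(S(=O)(=O)c3cccc(F)c3)ccc21)c1ncc[nH]1` gives 15.9 nM in this assay, the higher of the two numbers and beyond the scatter from compound 1. Compound 3 `COC(=O)NC[C@@H]1CCCc2cc(S(=O)(=O)c3cccc(F)c3)ccc21` differs from compound 2 by methoxy in place of 1H-imidazol-2-yl on a carbonyl carbon. For the measured compounds named here, no pair of measured compounds shows this change, so its direction is open; both compound 2 and compound 3 lack the basic amine of compound 1. The expected step of a 1.9-fold higher number from compound 2 to compound 3 (0.28 log units; within the scatter) is judged small, plausibly within the scatter. For compound 3 the estimate in this assay is 30 nM, within 8 nM to 120 nM.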

Compound 3, inhibition constant: 1.59 nM
Estimate against measurement, compound 3: 19-fold (1.28 log units) above; measured number outside the range, below it.
By their numbers in this assay, from the lowest: compound 1; then compound 3; then compound 2.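

In this assay, methoxy in place of 1H-imidazol-2-yl on a carbonyl carbon gives a 10-fold lower number from compound 2 to compound 3 (1.00 log units; beyond the scatter). For the compounds shown here, this is the first one-place step, and it shows that the group on this carbonyl carbon affects the read-out and that the five-membered aromatic ring is not needed for a low number here. Nothing shown explains why the number falls. On these data alone, whether ethoxy, methyl or a dimethylamino group on the same carbonyl carbon would give a lower or higher number remains open, as does whether the step holds on another core.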